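The compounds below may be only part of what the source reports. "The series", "measured", "known", "first", "only" and "open" are said of these compounds alone.

Measured compounds:
compound 1, `COc1ccc(N(C)Cc2nc3cc(C(F)(F)F)ccc3nc2-c2ccccc2)cc1`, 3000 nM
compound 2, `COc1ccc(N(C)Cc2nc3cc(C(F)(F)F)ccc3nc2-c2ccccc2)cc1OC`, 8000 nM
compound 3, `CCN(Cc1nc2cc(C(F)(F)F)ccc2nc1-c1ccccc1)c1ccc(OC)c(OC)c1`, 4000 nM

Of the compounds shown here, three have been tested in an assay on isolated protein for inhibition of Dihydrofolate reductase (Homo sapiens), read by spectrophotometry; a lower number here means a stronger inhibitor, a higher number a weaker inhibitor. Compound 1 gives 3000 nM in this assay, compound 2 gives 8000 nM, and compound 3 gives 4000 nM. Compound 2 is made from compound 1 by methoxy in place of hydrogen on an aromatic carbon, and this change gave a 2.7-fold higher number from compound 1 to compound 2 (0.43 log units; beyond the scatter). The second measured pair gives a 2.0-fold lower number from compound 2 to compound 3 (0.30 log units; within the scatter), a step that stays within the usual scatter. The cores of compound 1 and compound 3 differ in more than one place, and that difference is not broken down here.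

The unmeasured compound 4, `CCN(Cc1nc2cc(C(F)(F)F)ccc2nc1-c1ccccc1)c1cc(OC)c(OC)c(OC)c1`, is made from compound 3 by methoxy in place of hydrogen on an aromatic carbon. Going by the values given here, this is the same kind of change as the one from compound 1 to compound 2, with one point of difference in its surroundings: in compound 4 the entering methoxy is also meta to a methoxy group, which the earlier change was not. On the strength of a 2.7-fold higher number from compound 1 to compound 2 (0.43 log units; beyond the scatter), the author expects a step of about a 2.3-fold higher number from compound 3 to compound 4 (0.35 log units; beyond the scatter) in this assay, a step of similar size and the same direction as the earlier one, with added uncertainty because the new surroundings are not covered by any measured pair. Compound 4 is therefore estimated at 9000 nM, within a range from 3000 nM to 25000 nM.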

Compound 4, inhibition constant: 6000 nM
Beside the measured number, compound 4's estimate is 1.5-fold (0.18 log units) above it; measured number inside the range.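

In this assay, the methoxy in place of hydrogen that turns 3,4-dimethoxyphenyl into 3,4,5-trimethoxyphenyl gives a 1.5-fold higher number from compound 3 to compound 4 (0.18 log units; within the scatter), so on this core the step cannot be told apart from repeat measurement. Set beside the earlier step, the result gives no sign that the change behaves differently on the two cores: the same change on two cores in this assay, a 2.7-fold higher number (0.43 log units; beyond the scatter) from compound 1 to compound 2 and a 1.5-fold higher number (0.18 log units; within the scatter) from compound 3 to compound 4, 1.8-fold (0.25 log units) apart, within the scatter of two such steps. Going by these compounds alone, this shows only that the two steps cannot be separated, not that the change has one fixed size across the series, since the comparison rests on two pairs, only one step lies beyond the scatter, and the entering methoxy in compound 4 is also meta to a methoxy group, a setting with no second measured pair.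

The compounds shown leave open how the number would respond if a hydroxy group, an amine or a fluorine stood on the aromatic carbon in place of the entering methoxy. They also leave open whether the step would hold with a longer chain on the nitrogen, or with a nitrile in place of the trifluoromethyl on the shared core.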